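Fluorine on the benzyl ring of a coumarin amine series

The source may report more compounds than this note shows. Statements on the series, on what has been measured and on what is new or still open speak of the compounds shown alone.

Of the compounds shown here, three have been measured in an assay for inhibition of Amine oxidase [flavin-containing] B (Rattus norvegicus) (on this read-out higher numbers stand for weaker inhibition and lower numbers for stronger inhibition), and all share one core that carries a benzyl-ether arm on one side and an amine-bearing methylene on the other. Compound 1, `NC(=O)[C@@H]1CCCN1Cc1cc(=O)oc2cc(OCc3ccccc3)ccc12`, gives 380 nM in this assay. Compound 2, `NC(=O)[C@@H]1CCCN1Cc1cc(=O)oc2cc(OCc3cccc(F)c3)ccc12`, differs from compound 1 only in the ether arm; the change is fluoro in place of hydrogen on an aromatic carbon and it produced a 2.2-fold higher number from compound 1 to compound 2 (0.35 log units; beyond the scatter), leaving compound 2 at 850 nM. Compound 3, `CN(C)Cc1cc(=O)oc2cc(OCc3ccccc3)ccc12`, keeps the unchanged ether arm of compound 1 but carries a smaller amine: the difference is dimethylamino in place of 2-carbamoylpyrrolidin-1-yl on a saturated chain carbon bound to an aromatic carbon, and the step was a 4.7-fold higher number from compound 1 to compound 3 (0.68 log units; beyond the scatter), so compound 3 gives 1800 nM. Compound 2 and compound 3 were not compared directly; their values simply show compound 3 with the higher number of the two.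

Compound 4, `CN(C)Cc1cc(=O)oc2cc(OCc3cccc(F)c3)ccc12`, has not yet been measured. It stands to compound 3 as compound 2 stands to compound 1: the change is fluoro in place of hydrogen on an aromatic carbon, made at a place described in exactly the same words as for the pair of compound 1 and compound 2, so it is the same change, now on the core of compound 3 rather than that of compound 1. The cores differ by dimethylamino in place of 2-carbamoylpyrrolidin-1-yl on a saturated chain carbon bound to an aromatic carbon. Within the data shown here, only one prior instance of this change exists here, so the expectation leans on it alone. The step from compound 3 to compound 4 is expected to be a 2.1-fold higher number from compound 3 to compound 4 (0.32 log units; beyond the scatter), resting on a 2.2-fold higher number from compound 1 to compound 2 (0.35 log units; beyond the scatter). Compound 4 is therefore estimated at 3800 nM in this assay. The likely range for compound 4 runs from 1500 nM to 9500 nM.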

Compound 4, half-maximal inhibitory concentration: 510 nM
Compound 4: middle estimate off by 7.5-fold (0.87 log units), on the high side; the measured number lies below the stated range.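

In this assay, the fluoro change on the benzyl arm does not carry from one core to the other: on the core of compound 1 it gave a 2.2-fold higher number from compound 1 to compound 2 (0.35 log units; beyond the scatter), whereas on the core of compound 3 it gave a 3.5-fold lower number from compound 3 to compound 4 (0.55 log units; beyond the scatter), so the same small edit moved the number in opposite directions: the same change on two cores in this assay, a 2.2-fold higher number (0.35 log units; beyond the scatter) from compound 1 to compound 2 and a 3.5-fold lower number (0.55 log units; beyond the scatter) from compound 3 to compound 4, 7.9-fold (0.90 log units) apart, beyond the scatter of two such steps

Seen from the amine side, the same four compounds tell a matching story: with the plain benzyl arm, the amine swap gave a 4.7-fold higher number from compound 1 to compound 3 (0.68 log units; beyond the scatter), but with the 3-fluorobenzyl arm it gave a 1.7-fold lower number from compound 2 to compound 4 (0.22 log units; within the scatter), which leaves those two compounds indistinguishable: the same change on two cores in this assay, a 4.7-fold higher number (0.68 log units; beyond the scatter) from compound 1 to compound 3 and a 1.7-fold lower number (0.22 log units; within the scatter) from compound 2 to compound 4, 7.9-fold (0.90 log units) apart, beyond the scatter of two such steps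

This shows that, in these compounds, the effect of each change depends on what the other end of the molecule carries, so a step measured on one core is a poor guide to the next; it does not show why this happens, and one set of four compounds cannot establish how far the behaviour extends.

On these data alone, whether a chloro group in place of the fluoro would split the same way between the two cores remains open. So does the behaviour of the fluoro change alongside other amines, such as a plain pyrrolidin-1-yl or a diethylamino group.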